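Chloro substitution on a fused purine-type core

This account rests on a few compounds, and the source may have more. Where it says the series, first, only, none or still open, it means among the compounds named here.

Measured compounds:
compound 1 `ClCc1cccc(Cn2cnc3c(Cl)ncnc32)c1` — 20000 nM
compound 2 `ClCc1cccc(Cn2cnc3c(Cl)nc(Cl)nc32)c1` — 26900 nM
compound 3 `ClCc1ccccc1Cn1cnc2ncnc(Cl)c21` — 12900 nM

In a functional assay on 786-0 cells (Homo sapiens) for cytotoxicity, read by sulforhodamine B assay, with a stated time of 48 h (a higher number here means a weaker inhibitor of growth, a lower number a stronger inhibitor of growth), compound 1 gives 20000 nM and compound 2 gives 26900 nM. Compound 2 carries, relative to compound 1, the change (chloro in place of hydrogen on an aromatic carbon), and the step is a 1.3-fold higher number from compound 1 to compound 2 (0.13 log units; within the scatter). Compound 3 gives 12900 nM in this assay; its value and that of compound 1 lie within the scatter of each other, while its value and that of compound 2 lie beyond it. The difference between the core of compound 3 and the core of compound 1 is not broken down here.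

Compound 4 `ClCc1ccccc1Cn1cnc2nc(Cl)nc(Cl)c21` carries, relative to compound 3, the change (chloro in place of hydrogen on an aromatic carbon). The place is the same word for word as for the change from compound 1 to compound 2, so it is the same change. The step is expected to be a 1.3-fold higher number from compound 3 to compound 4 (0.12 log units; within the scatter), resting on the step of a 1.3-fold higher number from compound 1 to compound 2 (0.13 log units; within the scatter) seen for the one earlier case. Compound 4 is estimated at 17000 nM in this assay, with a likely range from 8000 nM to 36000 nM.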

Compound 4, concentration for total growth inhibition: 7070 nM
For compound 4 the middle estimate is 2.4-fold (0.38 log units) above the measured one, outside the stated range (below it).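

In this assay, chloro in place of hydrogen gives a 1.8-fold lower number from compound 3 to compound 4 (0.26 log units; within the scatter), while the earlier case gives a 1.3-fold higher number from compound 1 to compound 2 (0.13 log units; within the scatter). The two steps point in opposite directions on paper, but they cannot be told apart, so nothing here shows that the change behaves differently on the two cores: the same change on two cores in this assay, a 1.3-fold higher number (0.13 log units; within the scatter) from compound 1 to compound 2 and a 1.8-fold lower number (0.26 log units; within the scatter) from compound 3 to compound 4, 2.5-fold (0.39 log units) apart, within the scatter of two such steps. Two cases, each within the scatter, also do not show that the step carries over as a fixed amount, or that chloro at this place moves the number at all on either core.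

Still open, going by these compounds, is whether an amine or a methoxy group on the same aromatic carbon, between two ring nitrogen atoms, would give a step beyond the scatter on either core.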